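Working notes: from compound 2 to the untested compound 4

A few compounds are considered here, and "the series" means these few. Any claim that something is new, unique, unknown or untested is made for them only; others in the source may bear on it.

Of the compounds shown here, three of the shared core have been tested in a functional assay on A-375 cells (Homo sapiens) for antiproliferative activity, read by CCK-8 assay, with a stated time of 72 h, tested at 8 uM; on this read-out higher numbers stand for a stronger effect at the one concentration tested and lower numbers for a weaker effect. Compound 1 `CN(Cc1cccnc1)C(=S)SCc1ccc(C(=O)Nc2ccccc2N)cc1` gives 83.8%. Compound 2 `Nc1ccccc1NC(=O)c1ccc(CSC(=S)N2CCN(Cc3ccncc3)CC2)cc1` gives 89.5%, the highest of the three numbers; the gap to compound 1 lies within the scatter, so the two are not told apart, while compound 3 `Nc1ccccc1NC(=O)c1ccc(CSC(=S)N2CCN(C(c3ccccc3)c3ccccc3)CC2)cc1` gives 8.4%, beyond the scatter below compound 2. Compound 4 `Nc1ccccc1NC(=O)c1ccc(CSC(=S)N2CCN(c3ncccn3)CC2)cc1` is not yet measured. It differs from compound 2 in one place: pyrimidin-2-yl in place of (pyridin-4-yl)methyl on an amine nitrogen in a ring. Going by the values given here, no measured pair shares this change, so its size is unknown; compound 1 and compound 2 both bear a six-membered aromatic ring with 1 hetero atom in the varied region and both give high values, only compound 3 falls off. For compound 4 a value near 72% is expected, between 40% and 92%. The expected step of a number 17.5 percentage points lower from compound 2 to compound 4 (beyond the scatter) is a modest loss, at most a little beyond the scatter.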

Compound 4, a percentage reported as inhibition, at one concentration (the size of the read-out at that concentration, not a potency): 67.9%
For compound 4 the middle estimate is 4.1 percentage points above the measured one, and the stated range covers the measured number.
By their numbers in this assay, from the lowest: compound 3; then compound 4; then compounds 1 and 2 (each within the scatter of the next).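

In this assay, pyrimidin-2-yl in place of (pyridin-4-yl)methyl on the amine nitrogen in the ring gives a number 21.6 percentage points lower from compound 2 to compound 4 (beyond the scatter) as a modest loss. This position therefore keeps much of the effect with a six-membered aromatic ring with 2 hetero atoms, whereas compound 3 falls to 8.4% with its different group at this nitrogen. No measurement at hand explains the loss. Going by these compounds alone, the single step changes both the ring and the methyl link, so it does not tell which accounts for the loss. A pyridin-2-yl or (pyrimidin-2-yl)methyl group at this nitrogen would separate the two.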